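Chloro replaced by piperazin-1-yl on the shared core

This account rests on a few compounds, and the source may have more. Where it says the series, first, only, none or still open, it means among the compounds named here.

Measured so far:
Compound 1, `N#Cc1c(Cl)nc(SCc2nc3ccccc3[nH]2)nc1-c1ccccc1`: in a functional assay on HL-60 cells (Homo sapiens) for cytotoxicity, read by MTT assay, with a stated time of 3 days (a lower number here means a stronger inhibitor, a higher number a weaker inhibitor), compound 1 gives 4.46 nM.
Compound 2, `N#Cc1c(NC(N)=S)nc(SCc2nc3ccccc3[nH]2)nc1-c1ccccc1`: in this assay compound 2 gives 5.81 nM.

Compound 1 holds the lower of the two numbers, yet the step of a 1.3-fold higher number from compound 1 to compound 2 (0.11 log units; within the scatter) leaves it within the scatter of compound 2, so no order between the two is claimed. Compound 3, `N#Cc1c(-c2ccccc2)nc(SCc2nc3ccccc3[nH]2)nc1N1CCNCC1`, is the next member to be measured. It differs from compound 1 by piperazin-1-yl in place of chloro on an aromatic carbon. Among the compounds with values here, the only measured step touching the same aromatic carbon is the exchange of chloro made in compound 2, which gave a 1.3-fold higher number from compound 1 to compound 2 (0.11 log units; within the scatter). That single step is the whole guide; nothing yet measured involves a ring entering at this place. A step of small size is therefore expected for a 1.6-fold higher number from compound 1 to compound 3 (0.20 log units; within the scatter), with no direction favoured beyond the scatter. Compound 3 is estimated at 7 nM, within a range from 2 nM to 25 nM.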

Compound 3, half-maximal inhibitory concentration: 4 nM
Compound 3: the middle estimate sits 1.8-fold (0.24 log units) above what was measured, and the stated range covers the measured number.
By their numbers in this assay, from the lowest: compounds 3, 1 and 2 (each within the scatter of the next).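

In this assay, the aromatic carbon next to the ring nitrogen now carries a six-membered non-aromatic ring, and piperazin-1-yl in place of chloro gives a 1.1-fold lower number from compound 1 to compound 3 (0.05 log units; within the scatter). Against the ring-free group of compound 2, the same ring gives a 1.5-fold lower number from compound 2 to compound 3 (0.16 log units; within the scatter). A single chlorine, a ring-free group and a saturated ring therefore cannot be told apart at this carbon, so a ring entering here brings no readable difference in this read-out, and the three compounds carry no order. Nothing available accounts for this flat result.

Open, going by these compounds, is whether a carboxylic acid, a morpholine ring or an amine with a longer chain at this carbon would stay as close to compound 1. Also open, on these data alone, is whether an acetyl group on the piperazin-1-yl ring would leave the number in the same range.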